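A few compounds are considered here, and "the series" means these few. Any claim that something is new, unique, unknown or untested is made for them only; others in the source may bear on it.

Measured compounds:
- Compound 1 `ClCc1ccc(Cn2cnc3c(Cl)ncnc32)cc1`: 2450 nM
- Compound 2 `ClCc1cccc(Cn2cnc3c(Cl)ncnc32)c1`: 4070 nM

In a functional assay on NCI-H23 cells (Homo sapiens) for cytotoxicity, read by sulforhodamine B assay, with a stated time of 48 h (on this read-out lower numbers stand for stronger inhibition of growth and higher numbers for weaker inhibition of growth), compound 1 gives 2450 nM and compound 2 gives 4070 nM. The two numbers sit within the usual scatter of repeated measurements of this kind, so nothing separates compound 1 from compound 2 on these data; compound 1 simply holds the smaller of the two numbers shown.

Compound 3 `ClCc1ccc(Cn2cnc3c(Cl)nc(Cl)nc32)cc1` has not yet been measured. It differs from compound 1 by chloro in place of hydrogen on an aromatic carbon. Among the measured compounds shown here, no pair of measured compounds shows the effect of this change, so there is no measured step to rest on, and the expectation must come from compound 1 alone. With that, no step beyond the scatter is expected in this assay, in either direction, and the most likely outcome is that compound 3 returns a number close to that of compound 1.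

Compound 3 is therefore expected to give about 2000 nM in this assay, with a plausible range from 700 nM to 6000 nM. That estimate corresponds to an expected step of a 1.2-fold lower number from compound 1 to compound 3 (0.09 log units; within the scatter), a step that lies within the scatter.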

Compound 3, concentration for total growth inhibition: 23400 nM
Beside the measured number, compound 3's estimate is 12-fold (1.07 log units) below it; measured number above the stated range.
By their numbers in this assay, from the lowest: compounds 1 and 2 (each within the scatter of the next); then compound 3.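

In this assay, chloro in place of hydrogen on an aromatic carbon between two ring nitrogen atoms brings a 9.6-fold higher number from compound 1 to compound 3 (0.98 log units; beyond the scatter) and so weaker inhibition of growth, a step beyond the scatter. Compounds 1 and 2 differ only in how the chloromethyl-bearing ring is substituted and stay within the scatter of each other, so they gave no sign that the result could depend on this other position in the core. Compound 3 shows that adding one heavy atom there is enough to change the read-out, although the available evidence offers no explanation for this step.

The compounds shown leave open whether this loss belongs to chloro itself or would follow any replacement of that hydrogen, a question that an amine, a methoxy group or fluoro at the same place could help to settle. Among the compounds shown here, they also leave open whether chloro at this position would produce a similar step on the framework of compound 2, since only the pair built on compound 1 can be read here.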